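Methyl for methoxy on the pyrimidine-type core: compound 4

The source may report more compounds than this note shows. Statements on the series, on what has been measured and on what is new or still open speak of the compounds shown alone.

Measured so far:
compound 1 `COc1ncc(C(F)(F)F)c(N2CC[C@@H](C)N(C(=O)c3ccccc3-n3nccn3)CC2)n1`, 245 nM
compound 2 `Cc1cnc(Cl)nc1N1CC[C@@H](C)N(C(=O)c2ccccc2-n2nccn2)CC1`, 2600 nM
compound 3 `C[C@@H]1CCN(c2nc(Cl)ncc2Cl)CCN1C(=O)c1ccccc1-n1nccn1`, 3200 nM

In a functional assay on CHO cells for antagonist activity at Orexin receptor type 2 (Homo sapiens), read by FLIPR and calcium flux, with a stated time of 60 min (a higher number here means a weaker inhibitor, a lower number a stronger inhibitor), compound 1 gives the lowest of the three numbers; the nearest is compound 2, and compound 3 lies furthest away, both beyond the scatter. Compound 4 `Cc1ncc(C(F)(F)F)c(N2CC[C@@H](C)N(C(=O)c3ccccc3-n3nccn3)CC2)n1` differs from compound 1 by methyl in place of methoxy on an aromatic carbon. Within the data shown here, the only measured step, a 1.2-fold higher number from compound 2 to compound 3 (0.09 log units; within the scatter), concerns a different position and a different pair of groups, so no measured step bears directly on this change. With nothing in the series to go on, compound 4 is expected to lie near compound 1, with at most a modest step of a 1.6-fold higher number from compound 1 to compound 4 (0.21 log units; within the scatter); its value is estimated at 400 nM, ranging from 120 nM to 1500 nM.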

Compound 4, half-maximal inhibitory concentration: > 10000 nM
Compound 4: no number, only a limit (the forecaster's own chance of this, stated with the estimate: 3%); at least 25-fold (1.39 log units) between middle value and limit.
By their numbers in this assay, from the lowest: compound 1; then compounds 2 and 3 (each within the scatter of the next). At a limit, above all of these: compound 4.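

In this assay, the methoxy on the aromatic carbon between two ring nitrogen atoms cannot be exchanged for methyl without a large loss, with an at least 40-fold higher number from compound 1 to compound 4 (1.61 log units; beyond the scatter). Among these compounds, compound 4 gives > 10000 nM, which is a limit and not a number, so the full size of this step stays unknown: the limit of > 10000 nM in this assay, at which 1 of the 4 values shown sits. The only earlier step, at a different position, stayed within the scatter, so this is the first sign that a single small exchange can matter greatly. The compounds shown leave open whether the oxygen itself or the whole methoxy is needed here, and an ethoxy, a hydroxyl or an amine at this position could tell these apart.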